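Working notes on replacing 3-methoxyphenyl in compound 1

This account rests on a few compounds, and the source may have more. Where it says the series, first, only, none or still open, it means among the compounds named here.

Compound 1 `COc1cccc(-c2cc(-c3cc(C(C)C)c(O)cc3C)[nH]c(=O)c2C#N)c1` is the reference point for this step. In a functional assay for inhibition, tested at 80 ug/mL (on this read-out lower numbers stand for a weaker effect and higher numbers for a stronger effect at the one concentration tested), compound 1 gives 43%, the second highest of the three numbers recorded so far. The highest belongs to compound 2 `COc1ccc(-c2cc(-c3cc(C(C)C)c(O)cc3C)[nH]c(=O)c2C#N)cc1OC` with 58%; the step of a number 15 percentage points higher from compound 1 to compound 2 (beyond the scatter) is beyond the scatter. Compound 3 `Cc1cc(O)c(C(C)C)cc1-c1cc(-c2ccccc2[N+](=O)[O-])c(C#N)c(=O)[nH]1` gives 35%, and the step of a number 8 percentage points lower from compound 1 to compound 3 (within the scatter) lies within the scatter, so compounds 1 and 3 cannot be separated on these data. The step of a number 23 percentage points lower from compound 2 to compound 3 (beyond the scatter) is the only one that exceeds the scatter in the downward direction.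

The unmeasured compound 4 `Cc1cc(O)c(C(C)C)cc1-c1cc(-c2ccccc2Cl)c(C#N)c(=O)[nH]1` differs from compound 1 in one place: 2-chlorophenyl in place of 3-methoxyphenyl on an aromatic carbon. Going by the values given here, the step that bears most directly on this change is the one from compound 1 to compound 3, where 2-nitrophenyl took the place of 3-methoxyphenyl and the number moved only a number 8 percentage points lower from compound 1 to compound 3 (within the scatter). Among the compounds with values here, no measured step involves a chlorine, so the exchange of a nitro group for chlorine on the entering phenyl rests on no direct comparison. The expectation is therefore a step of about a number 5 percentage points lower from compound 1 to compound 4 (within the scatter), within the scatter. Compound 4 is estimated to give 38% in this assay, in the range from 22% to 54%.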

Compound 4, a percentage reported as inhibition, at one concentration (the size of the read-out at that concentration, not a potency): 32%
The estimate for compound 4 lay 6 percentage points above the measured number, and the stated range covers the measured number.
By their numbers in this assay, from the lowest: compounds 4, 3 and 1 (each within the scatter of the next, the first and the last beyond it); then compound 2.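

In this assay, going by these compounds alone, 2-chlorophenyl is the first replacement of 3-methoxyphenyl at this position to give a step that can be read, a number 11 percentage points lower from compound 1 to compound 4 (beyond the scatter). Chloro in place of nitro on the entering phenyl cannot be told apart, a number 3 percentage points lower from compound 3 to compound 4 (within the scatter), so this position does not separate 2-chlorophenyl from 2-nitrophenyl on these numbers, and the two sit together at the low end of the set. The gap to the 3,4-dimethoxyphenyl of compound 2 is also the widest seen so far, a number 26 percentage points lower from compound 2 to compound 4 (beyond the scatter), which suggests that the methoxy-bearing phenyl groups read higher than those with a group at the 2-position, although compound 3 goes against this by staying within the scatter of compound 1.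

No measurement is available that would explain any of these steps. On these data alone, it remains open how an unsubstituted phenyl, or a phenyl carrying an amine or a carboxylic acid, would read at this position, and whether these differences at a single concentration would carry over to potency.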